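The source may hold more compounds than are shown below. What is called first, only, known or untested is meant among the compounds shown, and "the series" means these compounds.

Compound 1 `CC(C)n1ncc2c(C(=O)Nc3ccccc3F)cc(-c3cccnc3)nc21`: 50000 nM
Compound 2 `CC(C)n1ncc2c(C(=O)Nc3ccc(F)c(S(N)(=O)=O)c3)cc(-c3cccs3)nc21`: 50000 nM
Compound 3 `CC(C)n1ncc2c(C(=O)N3CCc4cc(F)ccc43)cc(-c3cccs3)nc21`: > 200000 nM, a limit of the assay

All three were measured in an ADME assay on LLC-MK2 cells (Macaca mulatta) for cytotoxicity, read by spectrophotometry and crystal violet staining, with a stated time of 4 days; on this read-out higher numbers stand for lower toxicity in this test and lower numbers for higher toxicity in this test. Compound 2 stands level with compound 1 at the digits shown, within the usual scatter of this assay. For compound 3 only a limit is known, (the limit of > 200000 nM in this assay, at which 1 of the 3 values shown sits), so no number is available for it. Compound 4 `CC(C)n1ncc2c(C(=O)Nc3ccc(F)cc3)cc(-c3cccs3)nc21` has not yet been measured; it differs from compound 2 in a single place: hydrogen in place of sulfamoyl on an aromatic carbon. Among the measured compounds shown here, no two measured compounds differ from each other in one place, so no measured step guides this change. Taking compound 2 as the nearest point, no step beyond the scatter is expected from compound 2 to compound 4. Compound 4 is therefore expected to give about 50000 nM, between 20000 nM and 150000 nM, which means an expected step of no change at the digits printed from compound 2 to compound 4 (within the scatter).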

Compound 4, half-maximal cytotoxic concentration: > 200000 nM
Compound 4: only a limit was reported; the forecaster's own chance of this, stated with the estimate: 30%; middle value at least 4.0-fold (0.60 log units) away from the limit.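

In this assay, hydrogen in place of sulfamoyl on an aromatic carbon, ortho to a fluoro group, gives an at least 4.0-fold higher number from compound 2 to compound 4 (0.60 log units; beyond the scatter). Compound 4 gives > 200000 nM, which is a limit of the assay, so the step is bounded on one side only. Among the compounds shown here, this is the first single-place step, and it shows that this position is not silent on this read-out: the change goes toward lower toxicity in this test.

On these data alone, whether an amine or a carboxylic acid on this carbon would read like sulfamoyl or like hydrogen stays open. How far the true number for compound 4 lies past its limit also stays open: the limit of > 200000 nM in this assay, at which 2 of the 4 values shown sit.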